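Replacing the Methoxy Methyl with Hydrogen on a Shared Core

The source may hold more compounds than are shown below. What is called first, only, known or untested is meant among the compounds shown, and "the series" means these compounds.

Three compounds built on one shared core have been run in a functional assay, with a stated time of 30 min, tested at 20 uM; on this read-out higher numbers stand for more inhibition at the one concentration tested (going by the name of the read-out) and lower numbers for less inhibition. Compound 1 `c1ccc(-c2nnc(Nc3ncccn3)o2)cc1` gives 51.4% in this assay. Compound 2 `Cc1ccc(-c2nnc(Nc3ncccn3)o2)cc1` is reported only at a limit of this assay, < 20% (the limit of < 20% in this assay, at which 1 of the 3 values shown sits). Compound 3 `COc1ccc(-c2nnc(Nc3ncccn3)o2)cc1` gives 45.8% in this assay. Of the two numbers shown, compound 3 is one, and compound 1 is its nearest neighbour; the gap between them is a number 5.6 percentage points lower from compound 1 to compound 3 (within the scatter). The other measured steps are a number at least 31.4 percentage points lower from compound 1 to compound 2 (beyond the scatter) and a number at least 25.8 percentage points higher from compound 2 to compound 3 (beyond the scatter).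

Compound 4 `Oc1ccc(-c2nnc(Nc3ncccn3)o2)cc1` has not yet been measured in this assay. It differs from compound 3 by hydrogen in place of methyl on an oxygen on an aromatic ring. Within the data shown here, no measured step removes a methyl from an oxygen, so none bears on this change directly. The closest comparisons are the methyl placed on an aromatic carbon, a number at least 31.4 percentage points lower from compound 1 to compound 2 (beyond the scatter), which moved the read-out strongly, and the methoxy placed on an aromatic carbon, a number 5.6 percentage points lower from compound 1 to compound 3 (within the scatter), which hardly moved it. With such indirect guidance only, a small drift or no step beyond the scatter is expected. For compound 4 the expected step is a number 5.8 percentage points lower from compound 3 to compound 4 (within the scatter). Compound 4 is estimated at 40% in this assay, between 15% and 62%.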

Compound 4, a percentage reported as inhibition, at one concentration (the size of the read-out at that concentration, not a potency): 63.4%
The estimate for compound 4 lay 23.4 percentage points below the measured number; the whole stated range lies below it.
By their numbers in this assay, from the lowest: compounds 3 and 1 (each within the scatter of the next); then compound 4. At a limit, below all of these: compound 2.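

In this assay the methyl on this oxygen turns out not to be a silent passenger: hydrogen in its place gives a number 17.6 percentage points higher from compound 3 to compound 4 (beyond the scatter) and so lifts the read-out clear of the methoxy compound, which had stood within the scatter of the core without any group on this aromatic carbon. The hydroxy is also the only group shown that improves on that bare core, with a number 12 percentage points higher from compound 1 to compound 4 (beyond the scatter) as its measured step, so this carbon can carry a group that raises the read-out as well as one that lowers it. The choice of group here matters a great deal, as hydroxy in place of methyl on the aromatic carbon gives a number at least 43.4 percentage points higher from compound 2 to compound 4 (beyond the scatter) in the same assay, and the lower end of that step is not a number, since compound 2 stands at a limit: the limit of < 20% in this assay, at which 1 of the 4 values shown sits.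

As far as these compounds go, whether the gain belongs to the hydroxy alone stays open, since an amine, a fluorine or an ethoxy on the same aromatic carbon would each test it. The reason for the rise also stays open, and these percentages at one concentration do not give a potency.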